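A few compounds are considered here, and "the series" means these few. Any claim that something is new, unique, unknown or untested is made for them only; others in the source may bear on it.

Three compounds share one core and were tested in a functional assay on HCT-116 cells (Homo sapiens) for cytotoxicity, read by MTT assay, with a stated time of 48 h; on this read-out lower numbers stand for stronger inhibition and higher numbers for weaker inhibition. Compound 1 `Nc1nc(-c2ccccc2)cn1/N=C/c1cc2ccccc2nc1Cl` gives 6920 nM. Compound 2 `COc1ccc(-c2cn(/N=C/c3cc4ccccc4nc3Cl)c(N)n2)cc1` gives 31800 nM; the step of a 4.6-fold higher number from compound 1 to compound 2 (0.66 log units; beyond the scatter) brought in a methoxy group. Compound 3 `COc1ccc(-c2cn(/N=C/c3cc4cc(C)ccc4nc3Cl)c(N)n2)cc1` reaches only a limit of the assay and no number, > 50000 nM. The step of an at least 1.5-fold higher number from compound 2 to compound 3 (0.19 log units; that floor lies within the scatter) stays within the scatter. Compound 4 `Cc1ccc2nc(Cl)c(/C=N/n3cc(-c4ccc5ccccc5c4)nc3N)cc2c1` is not yet measured. Its change is naphthalen-2-yl in place of 4-methoxyphenyl on an aromatic carbon. The methoxy step weakened inhibition, and this change removes that methoxy while the methyl step was small, so a gain in this assay is expected, as in an at least 2.5-fold lower number from compound 3 to compound 4 (0.39 log units; beyond the scatter). Compound 4 is expected at 20000 nM, between 5000 nM and 60000 nM.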

Compound 4, half-maximal inhibitory concentration: 27400 nM
Beside the measured number, compound 4's estimate is 1.4-fold (0.14 log units) below it, and the stated range covers the measured number.
By their numbers in this assay, from the lowest: compound 1; then compounds 4 and 2 (each within the scatter of the next). At a limit, above all of these: compound 3.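

In this assay naphthalen-2-yl in place of 4-methoxyphenyl gives an at least 1.8-fold lower number from compound 3 to compound 4 (0.26 log units; that floor lies within the scatter) on this aromatic carbon of the five-membered ring. As far as these compounds go, a group with two six-membered aromatic rings of carbon only therefore still gives a measured number here, though the true size of the change stays unknown. The entry for compound 3 is a limit of the assay and not a number: the limit of > 50000 nM in this assay, at which 1 of the 4 values shown sits.

From the compounds shown here alone, what stays open is how an amine or a carboxylic acid on the aromatic group at this position would read, and how naphthalen-2-yl would read on the core without the methyl.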